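Replacing an acetamide by an ethylurea on the pyrrolidine series

The source may hold more compounds than are shown below. What is called first, only, known or untested is meant among the compounds shown, and "the series" means these compounds.

Measured compounds:
- compound 1, `CCCC(=O)NCCCc1cccc2oc(CCCCc3ccccc3)cc12`, gives 16 nM in an assay on NIH3T3 cells for binding affinity to melatonin receptor type 1A (Homo sapiens); a lower number here means a stronger inhibitor, a higher number a weaker inhibitor
- compound 2, `CC(C)C(=O)NCCCc1cccc2oc(CCCCc3ccccc3)cc12`, gives 3.7 nM in this assay
- compound 3, `CC(=O)N[C@H]1CCN(c2cccc3oc(CCCCc4ccccc4)cc23)C1`, gives 22 nM in this assay

Compound 3 has the highest number of the three, but its gap to compound 1 is within the scatter, and only a 5.9-fold higher number from compound 2 to compound 3 (0.77 log units; beyond the scatter) marks a difference that is beyond it. Compound 4, `CCNC(=O)N[C@H]1CCN(c2cccc3oc(CCCCc4ccccc4)cc23)C1`, differs from compound 3 in one place: ethylamino in place of methyl on a carbonyl carbon.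

Going by the values given here, only one of the measured steps touches the group on the carbonyl carbon: a 4.3-fold lower number from compound 1 to compound 2 (0.64 log units; beyond the scatter), where one alkyl was exchanged for another. Among the compounds with values here, no measured step tests an alkylamino group in that position, so the present change is untested. Given that the one measured change at this position moved the number only modestly, the step from compound 3 to compound 4 is expected to be small, a 1.4-fold higher number from compound 3 to compound 4 (0.13 log units; within the scatter), with the direction uncertain. Compound 4 is therefore estimated at 30 nM, within a range from 8 nM to 120 nM.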

Compound 4, inhibition constant: 39 nM
The estimate for compound 4 lay 1.3-fold (0.11 log units) below the measured number; low and high end bracket the measured number.
By their numbers in this assay, from the lowest: compound 2; then compounds 1, 3 and 4 (each within the scatter of the next, the first and the last beyond it).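

Putting ethylamino in place of methyl on this carbonyl carbon, which turns acetamido into (ethylcarbamoyl)amino, gives a 1.8-fold higher number from compound 3 to compound 4 (0.25 log units; within the scatter) in this assay and so cannot be told apart from no change. Going by these compounds alone, the earlier step at a carbonyl carbon exchanged only one alkyl group for another, whereas this one shows that a larger group with a nitrogen and one extra hydrogen-bond donor can sit here without a clear loss of binding affinity. No separate measurement helps to explain this result.

A methylamino or propylamino group on the same carbonyl carbon would show whether the length of the chain matters here. A dimethylamino group, which has no hydrogen on that nitrogen, would show whether the added donor matters.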